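Swapping Methyl for Nitro on a Shared Hydrazone Core

The compounds below may be only part of what the source reports. "The series", "measured", "known", "first", "only" and "open" are said of these compounds alone.

Of the compounds shown here, three built on the same core have so far been tested in a functional assay on K562 cells (Homo sapiens) for cytotoxicity, read by MTT assay, with a stated time of 72 h (a higher number here means a weaker inhibitor, a lower number a stronger inhibitor), for their effect on leukemia cells. Compound 1 `c1ccc(NN=C(c2nc3ccccc3[nH]2)c2nc3ccccc3[nH]2)cc1` carries a hydrogen on the outer aromatic ring and gives 144000 nM in this assay. Compound 2 `Cc1ccc(NN=C(c2nc3ccccc3[nH]2)c2nc3ccccc3[nH]2)cc1` carries a methyl group there and gives 239000 nM in this assay, while compound 3 `Clc1ccc(NN=C(c2nc3ccccc3[nH]2)c2nc3ccccc3[nH]2)cc1` carries a chloro group and gives 159000 nM in this assay. Compound 2 has the highest of the three numbers, yet every gap is small: the step of a 1.7-fold higher number from compound 1 to compound 2 (0.22 log units; within the scatter) and the step of a 1.5-fold lower number from compound 2 to compound 3 (0.18 log units; within the scatter) both fall within the scatter, as does the step of a 1.1-fold higher number from compound 1 to compound 3 (0.04 log units; within the scatter) in the same assay. In other words, hydrogen, methyl and chloro at that spot are indistinguishable here.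

Compound 4 `O=[N+]([O-])c1ccc(NN=C(c2nc3ccccc3[nH]2)c2nc3ccccc3[nH]2)cc1` differs from compound 2 by a single change, nitro in place of methyl on an aromatic carbon at that same spot. Going by the values given here, no measured step involves a nitro group, so the only guidance is that the three earlier swaps at this position moved nothing beyond the scatter. Compound 4 is therefore expected to give about 200000 nM in this assay, most plausibly between 80000 nM and 500000 nM in this assay. The expected step of a 1.2-fold lower number from compound 2 to compound 4 (0.08 log units; within the scatter) is one that would sit within the scatter.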

Compound 4, half-maximal inhibitory concentration: 101000 nM
Compound 4: the middle estimate sits 2.0-fold (0.30 log units) above what was measured; the range from low to high includes it.
By their numbers in this assay, from the lowest: compounds 4, 1, 3 and 2 (each within the scatter of the next, the first and the last beyond it).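

Nitro is the first group at this spot on the outer aromatic ring to open a gap beyond the scatter in this assay, with a 2.4-fold lower number from compound 2 to compound 4 (0.37 log units; beyond the scatter) being a modest step, whereas no swap among hydrogen, methyl and chloro got that far. That gap holds against only one partner, since a 1.6-fold lower number from compound 3 to compound 4 (0.20 log units; within the scatter) and a 1.4-fold lower number from compound 1 to compound 4 (0.15 log units; within the scatter) both stay within the scatter, so the position responds to this one change from methyl to nitro, and compound 4 cannot be placed apart from compound 1 or compound 3. Nothing available speaks to what lies behind the step from methyl to nitro.

From the compounds shown here alone, because only one spot on the shared core varies across these compounds, it remains open whether an amine or a carboxylic acid there would move the number further than nitro does. Going by these compounds, whether the same change from 4-methylphenyl to 4-nitrophenyl would give a step of similar size on a different core also remains open.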